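The source may report more compounds than this note shows. Statements on the series, on what has been measured and on what is new or still open speak of the compounds shown alone.

Series notes. Compound 1 `Cc1ccnc(/C(N)=N/NC(=S)N2CCOCC2)c1`, compound 3 `Cc1ccnc(/C(N)=N/NC(=S)N2CCSCC2)c1` and compound 2 `Cc1cccc(/C(N)=N/NC(=S)N2CCSCC2)n1` have been tested in a functional assay on A-431 cells (Homo sapiens) for cytotoxicity, read by MTT assay, with a stated time of 72 h, tested at 10 uM; a lower number here means less inhibition of growth, a higher number more inhibition of growth at the concentration tested. Compound 1 gives 62%, compound 3 gives 60% and compound 2 gives 53.2%. Compounds 2 and 3 are built from the same atoms joined differently; the difference between the two cores is not broken down here. Compound 1 arises from compound 3 by one change: morpholin-4-yl in place of thiomorpholin-4-yl on a thiocarbonyl carbon. The step of a number 2 percentage points higher from compound 3 to compound 1 (within the scatter) is small. Compound 4 `Cc1cccc(/C(N)=N/NC(=S)N2CCOCC2)n1` is not yet measured. It arises from compound 2 by the same change at the same place: morpholin-4-yl in place of thiomorpholin-4-yl on a thiocarbonyl carbon. Given the step from compound 3 to compound 1 a number 2 percentage points higher from compound 3 to compound 1 (within the scatter), the step from compound 2 to compound 4 is expected to be of similar size, a number 1.8 percentage points higher from compound 2 to compound 4 (within the scatter). Compound 4 is therefore estimated to give 55% in this assay, with a likely range from 45% to 66%.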

Compound 4, percent growth inhibition at one concentration: 68.1%
Compound 4: the middle estimate sits 13.1 percentage points below what was measured, outside the stated range (above it).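

In this assay, morpholin-4-yl in place of thiomorpholin-4-yl on a thiocarbonyl carbon gives a number 14.9 percentage points higher from compound 2 to compound 4 (beyond the scatter). Set beside the same change on the other core, the two steps cannot be told apart: the same change on two cores in this assay, a number 2 percentage points higher (within the scatter) from compound 3 to compound 1 and a number 14.9 percentage points higher (beyond the scatter) from compound 2 to compound 4, 12.9 percentage points apart, within the scatter of two such steps This does not show that the core alters the size of the step, nor does it show that the step is the same on both cores, since each core supplies only one pair.

The compounds shown leave open how other groups on the thiocarbonyl carbon, such as piperidin-1-yl or an open-chain dimethylamino group, would compare with morpholin-4-yl and thiomorpholin-4-yl. On these data alone, whether the methyl group on the core contributes to these numbers also remains open.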